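A ring swap on the amide carbonyl of an inactive pair

This account rests on a few compounds, and the source may have more. Where it says the series, first, only, none or still open, it means among the compounds named here.

Compound 1, `CCn1ncc(-c2nc3c(O[C@H]4CCN(C(=O)C5CCOCC5)C4)ncnc3n2C)c1C`, in an ADME assay on isolated protein for inhibition of phosphodiesterase 7 (Homo sapiens); on this read-out lower numbers stand for stronger inhibition and higher numbers for weaker inhibition: > 50000 nM
Compound 2, `CCC(=O)N1CC[C@H](Nc2ncnc3c2nc(-c2cnn(CC)c2C)n3C)C1`, in this assay: > 20000 nM

Both measured values are limits of this assay rather than numbers. Compound 2 sits at the limit of > 20000 nM in this assay, at which 1 of the 2 values shown sits. Compound 1 sits at the limit of > 50000 nM in this assay, at which 1 of the 2 values shown sits. Compound 2 therefore stands nowhere in particular on the numbers shown: it is one of two compounds for which this assay gives only a limit, and no step between measured compounds is known.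

Compound 3, `CCn1ncc(-c2nc3c(N[C@H]4CCN(C(=O)C5CCOCC5)C4)ncnc3n2C)c1C`, keeps the whole of compound 2 except for one change: oxan-4-yl in place of ethyl on a carbonyl carbon. This is the same oxan-4-yl carbonyl that compound 1 carries on its ring nitrogen, and compound 1 is itself at a limit in this assay.

Among the compounds with values here, with no measured step to lean on, no change beyond the scatter is expected from compound 2 to compound 3; the step that the limit leaves unreadable from compound 2 to compound 3 is an estimate of essentially no movement, and compound 3 is expected to stay at or past the limit. The estimate for compound 3 in this assay is 40000 nM, with a range from 10000 nM to 100000 nM.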

Compound 3, half-maximal inhibitory concentration: > 20000 nM
Compound 3: no number, only a limit; the forecaster's own chance of this, stated with the estimate: 85%; the middle value lies beyond the limit too.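

In this assay, compound 3 gives > 20000 nM, which is a limit and not a number. Compound 2 also stands at a limit, so no step can be read from compound 2 to compound 3. The compounds shown leave open whether oxan-4-yl in place of ethyl on a carbonyl carbon changes inhibition at all.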